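The source may report more compounds than this note shows. Statements on the series, on what has been measured and on what is new or still open speak of the compounds shown alone.

In a functional assay on A549 cells (Homo sapiens) for antiproliferative activity, read by sulforhodamine B assay, with a stated time of 72 h (a lower number here means a stronger inhibitor, a higher number a weaker inhibitor), compound 1 `COc1cccc(/C=C2\CCC=CC2=O)c1` gives 1480 nM and compound 2 `COc1cc(/C=C2\CCC=CC2=O)cc(OC)c1` gives 4740 nM, so compound 2 holds the higher of the two numbers. Compound 3 `COc1cc(/C=C2\CCC=CC2=O)cc(OC)c1O` differs from compound 2 by one substitution, hydroxy in place of hydrogen on an aromatic carbon. For the measured compounds named here, only one measured step bears on this, the modest 3.2-fold higher number from compound 1 to compound 2 (0.51 log units; beyond the scatter), and it involves methoxy, a different group. That offers little guidance, so no clear direction is expected, and the estimated change, a 1.4-fold lower number from compound 2 to compound 3 (0.13 log units; within the scatter), stays within the scatter. For compound 3 the expected value is 3500 nM, with an estimated range from 1000 nM to 12000 nM.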

Compound 3, half-maximal inhibitory concentration: 1540 nM
The estimate for compound 3 lay 2.3-fold (0.36 log units) above the measured number, and the stated range covers the measured number.
By their numbers in this assay, from the lowest: compounds 1 and 3 (each within the scatter of the next); then compound 2.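

On the aromatic carbon ortho to two methoxy groups and para to a group of 8 heavy atoms, hydroxy in place of hydrogen gives, in this assay, a 3.1-fold lower number from compound 2 to compound 3 (0.49 log units; beyond the scatter) on this core. For the compounds shown here, the number can therefore fall with a change at this carbon, whereas the one earlier step, a 3.2-fold higher number from compound 1 to compound 2 (0.51 log units; beyond the scatter), moved it upward with methoxy as the entering group. Nothing available explains this drop. Going by these compounds, whether an amine, a carboxylic acid or a longer chain at this carbon would lower the number as well remains open.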